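The source may hold more compounds than are shown below. What is called first, only, known or untested is meant among the compounds shown, and "the series" means these compounds.

In a functional assay on Jurkat cells (Homo sapiens) (on this read-out higher numbers stand for weaker inhibition and lower numbers for stronger inhibition), compound 1 `CC(C)[C@H](NC(=O)COc1cccc2ccccc12)C(=O)N[C@@H](CC(=O)O)C(=O)COc1cccc2ccccc12` gives > 100000 nM, which is a limit and not a number. Going by the values given here, compound 2 `CC(C)[C@H](NC(=O)COc1cccc2ccccc12)C(=O)N[C@@H](CC(=O)O)C(=O)COc1c(F)c(F)c(F)c(F)c1F` gives 3050 nM, the only true number so far. Among the compounds with values here, the sole measured step, an at least 32-fold lower number from compound 1 to compound 2 (1.51 log units; beyond the scatter), is large and rests on (the limit of > 100000 nM in this assay, at which 1 of the 2 values shown sits). Compound 3 `CC(C)[C@H](NC(=O)COc1cccc2ccccc12)C(=O)N[C@@H](CC(=O)O)C(=O)COc1c(Cl)cccc1Cl` brings (2,6-dichlorophenyl in place of 2,3,4,5,6-pentafluorophenyl on an oxygen on a saturated carbon), with 2,6-dichlorophenyl in place of 2,3,4,5,6-pentafluorophenyl on an oxygen on a saturated carbon. That earlier step changed the same place, so this group is expected to matter as well. A moderate move to a higher number in this assay, meaning weaker inhibition, is expected: a 3.3-fold higher number from compound 2 to compound 3 (0.52 log units; beyond the scatter). The estimate for compound 3 is 10000 nM, with an expected range of 2000 nM to 60000 nM.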

Compound 3, half-maximal inhibitory concentration: 3000 nM
For compound 3 the middle estimate is 3.3-fold (0.52 log units) above the measured one, within the range that was stated.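

In this assay, 2,6-dichlorophenyl and 2,3,4,5,6-pentafluorophenyl on this oxygen cannot be told apart: a 1.0-fold lower number from compound 2 to compound 3 (0.01 log units; within the scatter). The advantage over naphthalen-1-yl at this position is therefore not confined to the pentafluorinated group, as a phenyl ring carrying chlorine also shows it: an at least 33-fold lower number from compound 1 to compound 3 (1.52 log units; beyond the scatter). Compound 1 stands at a limit, so this step gives only a bound: the limit of > 100000 nM in this assay, at which 1 of the 3 values shown sits.

Going by these compounds, whether halogen on this ring is needed at all remains open. A plain phenyl or a 2,6-dimethylphenyl in the same place would address that.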